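One ring group exchanged for a smaller one

The compounds below may be only part of what the source reports. "The series", "measured", "known", "first", "only" and "open" are said of these compounds alone.

In a functional assay (aorta) with Rattus norvegicus as the target, in the presence of a further agent that is not named here (on this read-out lower numbers stand for an effect already at smaller amounts and higher numbers for an effect only at larger amounts of compound), compound 1 (`COC(=O)C1=C(C)N=C(C)/C(=C(/O)OC)C1c1ccccc1OCCO[N+](=O)[O-]`) gives 56 nM and compound 2 (`COC(=O)C1=C(C)N=C(C)/C(=C(/O)OC)C1c1ccccc1OCc1no[n+]([O-])c1C(N)=O`) gives 550 nM, so compound 2 holds the higher of the two numbers. Compound 3 (`COC(=O)C1=C(C)N=C(C)/C(=C(/O)OC)C1c1ccccc1OCc1c(C#N)no[n+]1[O-]`) has not yet been measured. It departs from compound 2 in one place: a group of 8 heavy atoms (3 carbon, 3 nitrogen, 2 oxygen; one five-membered aromatic ring with 3 hetero atoms) in place of a group of 9 heavy atoms (3 carbon, 3 nitrogen, 3 oxygen; one five-membered aromatic ring with 3 hetero atoms), on a saturated chain carbon bound to an oxygen on an aromatic ring. Within the data shown here, only one measured step bears on this, and only indirectly: a 9.8-fold higher number from compound 1 to compound 2 (0.99 log units; beyond the scatter), where a group with no ring gave way to a ring-bearing group at that same place. Among the measured compounds shown here, it shows that this assay responds to changes there, but no measurement yet compares one ring group with another. A modest move towards a lower number is therefore expected, with the direction uncertain. The expected step is a 2.2-fold lower number from compound 2 to compound 3 (0.34 log units; beyond the scatter). For compound 3 the estimated value is 250 nM, with an expected range from 70 nM to 900 nM.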

Compound 3, half-maximal effective concentration: 9.4 nM
For compound 3 the middle estimate is 27-fold (1.42 log units) above the measured one; measured number below the stated range.
By their numbers in this assay, from the lowest: compound 3; then compound 1; then compound 2.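

The result shows that, at the saturated chain carbon bound to an oxygen on an aromatic ring, the presence of a ring group does not by itself fix the read-out in this assay: two groups that each hold a five-membered aromatic ring with 3 hetero atoms are separated by a 59-fold lower number from compound 2 to compound 3 (1.77 log units; beyond the scatter). The earlier rise on moving to a ring-bearing group also does not hold for every such group, as the group in compound 3 gives a 6.0-fold lower number from compound 1 to compound 3 (0.78 log units; beyond the scatter). Nothing available here accounts for the gap between the two ring groups.

The compounds shown leave open whether the lower number goes with the triple bond that enters or with the loss of the hydrogen-bond donor. They also leave open how a carboxylic acid or a methyl ester on that ring would read, or a longer chain in place of the single saturated carbon.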